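Moving the methoxy group to 2-methoxyphenyl in a small series

A few compounds are considered here, and "the series" means these few. Any claim that something is new, unique, unknown or untested is made for them only; others in the source may bear on it.

Measured in a functional assay on PC-3 cells (Homo sapiens) for cytotoxicity; on this read-out lower numbers stand for an effect already at smaller amounts and higher numbers for an effect only at larger amounts of compound:
- compound 1 `COC1=C(C)C(=O)/C(=C(O)/C=C/c2ccc(Br)cc2)C(=O)C1(C)C` gives 17.7 ug/mL
- compound 2 `COC1=C(C)C(=O)/C(=C(O)/C=C/c2ccc(OC)cc2)C(=O)C1(C)C` gives 18.2 ug/mL
- compound 3 `COC1=C(C)C(=O)/C(=C(O)/C=C/c2cccc(OC)c2)C(=O)C1(C)C` gives 14.3 ug/mL

Compound 3 stands level with the other two, as a 1.2-fold lower number from compound 1 to compound 3 (0.09 log units; within the scatter) and a 1.3-fold lower number from compound 2 to compound 3 (0.10 log units; within the scatter) both stay within the scatter. Compound 4 `COC1=C(C)C(=O)/C(=C(O)/C=C/c2ccccc2OC)C(=O)C1(C)C` carries 2-methoxyphenyl in place of 3-methoxyphenyl on a double-bonded chain carbon bound to a double-bonded chain carbon. Within the data shown here, the closest precedent is the change from 4-methoxyphenyl to 3-methoxyphenyl, a 1.3-fold lower number from compound 2 to compound 3 (0.10 log units; within the scatter), and even the exchange of bromo for methoxy, a 1.0-fold higher number from compound 1 to compound 2 (0.01 log units; within the scatter), stays within the scatter. Among the measured compounds shown here, no measured compound carries 2-methoxyphenyl, so this is an extrapolation, and no step beyond the scatter is expected in this assay. The expected step is a 1.1-fold higher number from compound 3 to compound 4 (0.03 log units; within the scatter). The estimate for compound 4 is 15.5 ug/mL, with an expected range of 9 ug/mL to 26 ug/mL.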

Compound 4, concentration for half-maximal effect: 15.6 ug/mL
Estimate against measurement, compound 4: 1.0-fold (0.00 log units) below; low and high end bracket the measured number.
By their numbers in this assay, from the lowest: compounds 3, 4, 1 and 2 (each within the scatter of the next).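

In this assay, 2-methoxyphenyl now joins 3-methoxyphenyl and 4-methoxyphenyl on the double-bonded chain carbon, and both a 1.1-fold higher number from compound 3 to compound 4 (0.04 log units; within the scatter) and a 1.2-fold lower number from compound 2 to compound 4 (0.07 log units; within the scatter) show that moving the methoxy group around the ring has changed nothing measurable. The exchange against the bromo compound, a 1.1-fold lower number from compound 1 to compound 4 (0.05 log units; within the scatter), agrees, so no change at this position among the four compounds has yet moved the read-out beyond the scatter. No evidence is available to explain this flat result. On these data alone, whether an amine or a carboxylic acid on this ring would shift the number remains open, as does the effect of changes to the shared core.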